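From a free amine to a piperidine: compound 4 awaits measurement

A few compounds are considered here, and "the series" means these few. Any claim that something is new, unique, unknown or untested is made for them only; others in the source may bear on it.

Four compounds with a shared core are considered here: compound 1 `NCCNc1cc(N2CCCc3ccccc3C2)nc2c(Cl)cccc12`, compound 2 `Cc1ccc2nc(N3CCCc4ccccc4C3)cc(NCCN)c2c1`, compound 3 `Cc1ccc2nc(N3CCCc4ccc(F)cc4C3)cc(NCCN)c2c1` and the not yet measured compound 4 `Cc1ccc2nc(N3CCCc4ccc(F)cc4C3)cc(NCCN3CCCCC3)c2c1`. In an ADME assay on HEp-2 cells (Homo sapiens) for cytotoxicity, read by CCK-8 assay, with a stated time of 5 days (on this read-out higher numbers stand for lower toxicity in this test and lower numbers for higher toxicity in this test), compound 1 gives 25000 nM, and in this assay compound 2 gives 9400 nM. For compound 3 this assay reports only a limit, > 3200 nM, and the limit of > 3200 nM in this assay, at which 1 of the 3 values shown sits, is where one of the three values sits. The step that the limit leaves unreadable from compound 2 to compound 3 is therefore left unreadable. Compound 4 differs from compound 3 by piperidin-1-yl in place of amino on a saturated chain carbon, two bonds along the chain from a nitrogen on an aromatic ring. No measured step touches this exchange, and the single counted step is unreadable, so the numbers shown give no direction. The estimated step that the limit leaves unreadable from compound 3 to compound 4 is expected to stay within the scatter. Compound 4 is accordingly estimated at 6000 nM in this assay, expected between 2000 nM and 20000 nM.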

Compound 4, half-maximal cytotoxic concentration: 22000 nM
The estimate for compound 4 lay 3.7-fold (0.56 log units) below the measured number; measured number outside the range, above it.
By their numbers in this assay, from the lowest: compound 2; then compounds 4 and 1 (each within the scatter of the next).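

The change from compound 3 to compound 4 cannot be read as a step, because compound 3 carries only a limit: the limit of > 3200 nM in this assay, at which 1 of the 4 values shown sits. In this assay the compounds shown leave open how far piperidin-1-yl in place of amino moves the number.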